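Trimming an Amide Side Chain on a Growth-Inhibiting Scaffold

The source may hold more compounds than are shown below. What is called first, only, known or untested is meant among the compounds shown, and "the series" means these compounds.

Of the compounds shown here, three have so far been tested in a functional assay on Huh-7 cells (Homo sapiens) for antiproliferative activity, read by CCK-8 assay, with a stated time of 72 h; on this read-out lower numbers stand for stronger inhibition of growth and higher numbers for weaker inhibition of growth. Compound 1 `CC[C@@H]1C(=O)N(C)c2cnc(Nc3ccc(S(=O)(=O)NC4CCCC4)cc3)nc2N1C1CCCC1` gives 389 nM in this assay, and compound 3 `CCCNC(=O)c1ccc2c(ccn2-c2ncc3c(n2)N(C2CCCC2)[C@H](CC)C(=O)N3C)c1` gives 689 nM. Compound 2 `CCC1C(=O)N(C)c2cnc(-n3ccc4cc(C(=O)NCC(C)C)ccc43)nc2N1c1ccn(C)n1` gives 5070 nM, the highest of the three numbers and therefore the weakest inhibition of growth among them; its gap to each of the other two lies beyond the usual scatter of repeated measurements.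

Compound 4 `CCNC(=O)c1ccc2c(ccn2-c2ncc3c(n2)N(c2ccn(C)n2)C(CC)C(=O)N3C)c1` has not yet been measured. It differs from compound 2 in a single place: methyl in place of isopropyl on a saturated chain carbon bound to an amide-type nitrogen. Everything else in the molecule is kept as it is in compound 2.

Going by the values given here, no measured pair in this set differs by exactly this change, so there is no direct precedent for how large a step it brings. Compound 3 gives a lower number than compound 2, but it differs from compound 2 in more than one place, so its value says nothing about this single change on its own. On that thin basis the step is expected to be small, a 1.4-fold lower number from compound 2 to compound 4 (0.16 log units; within the scatter), most likely within the scatter and, if anything, toward a slightly lower number. Compound 4 is estimated at 3500 nM, with a range from 1200 nM to 10000 nM.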

Compound 4, concentration for 50% growth inhibition: 20300 nM
Compound 4: middle estimate off by 5.8-fold (0.76 log units), on the low side; measured number outside the range, above it.
By their numbers in this assay, from the lowest: compounds 1 and 3 (each within the scatter of the next); then compound 2; then compound 4.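

In this assay, replacing the isobutylcarbamoyl side chain with ethylcarbamoyl gives a 4.0-fold higher number from compound 2 to compound 4 (0.60 log units; beyond the scatter), with everything else in the molecule unchanged. Going by these compounds alone, this is the first single-place step in the set, and it shows that this position is not indifferent to the size of the chain: methyl in place of isopropyl on a saturated chain carbon bound to an amide-type nitrogen weakens growth inhibition, modestly but beyond the usual scatter. No measurement here bears on why the number rises, so the step stands as an observation without an explanation.

A single step shows only the effect of going from isobutyl to ethyl, so it leaves open what a longer chain, or a chain ending in an amine or a carboxylic acid, would do in place of isobutyl. It also leaves open whether the same change would bring a step of similar size on another core.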